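A smaller aromatic ring on the shared core

This account rests on a few compounds, and the source may have more. Where it says the series, first, only, none or still open, it means among the compounds named here.

Of the compounds shown here, three have been tested in a functional assay on HCT-116 cells (Homo sapiens), read by MTT assay, with a stated time of 72 h; on this read-out lower numbers stand for stronger inhibition and higher numbers for weaker inhibition. Compound 1 `O=c1[nH]cnc2c1c(-c1ccsc1)cn2[C@@H]1O[C@H](CO)[C@@H](O)[C@H]1O` gives > 20000 nM, which is a limit of the assay rather than a number. Compound 2 `O=c1[nH]cnc2c1c(-c1cc3ccccc3o1)cn2[C@@H]1O[C@H](CO)[C@@H](O)[C@H]1O` likewise gives > 20000 nM, again only a limit. Compound 3 `Cc1nc(N)c2c(-c3cc4ccccc4o3)cn([C@@H]3O[C@H](CO)[C@@H](O)[C@H]3O)c2n1` also gives > 20000 nM, a limit as well. The change from compound 2 to compound 1 is thiophen-3-yl in place of 1-benzofuran-2-yl on an aromatic carbon, and the step that the two limits leave unreadable from compound 2 to compound 1 cannot be read because of the limit of > 20000 nM in this assay, at which 3 of the 3 values shown sit. The cores of compound 2 and compound 3 differ, but the difference between the two cores is not broken down here. Compound 4 `Cc1nc(N)c2c(-c3ccsc3)cn([C@@H]3O[C@H](CO)[C@@H](O)[C@H]3O)c2n1` has not yet been measured; it arises from compound 3 by thiophen-3-yl in place of 1-benzofuran-2-yl on an aromatic carbon, the same change as that from compound 2 to compound 1. For compound 4 the expected step is a step that the limit leaves unreadable from compound 3 to compound 4, most likely ending again at a limit. This rests on compound 3 standing at a limit, > 20000 nM. It also rests on the step that the two limits leave unreadable from compound 2 to compound 1, whose size is not readable. Compound 4 is therefore estimated at 30000 nM, between 10000 nM and 100000 nM.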

Compound 4, half-maximal inhibitory concentration: > 20000 nM
Compound 4 was reported as a limit; the forecaster's own chance of this, stated with the estimate: 85%; the middle value is on the limit's open side.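

Compound 3 and compound 4 both stop at a limit rather than a number in this assay, so the step between them cannot be read, because the read-out gives no number here: the limit of > 20000 nM in this assay, at which 4 of the 4 values shown sit. The compounds shown leave open whether thiophen-3-yl in place of 1-benzofuran-2-yl changes the inhibition at all.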